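The source may hold more compounds than are shown below. What is called first, only, known or untested is meant among the compounds shown, and "the series" means these compounds.

Compound 1 `CCOc1cc([C@](O)(CCN(C)C)[C@@H](c2cc3cc(Br)ccc3nc2OC)c2cccc(OC)c2F)cc(OC)n1` is an intermediate with a shared core, and in an ADME assay on microsomes from liver (Mus musculus) for metabolic stability (on this read-out lower numbers stand for slow clearance and higher numbers for fast clearance), compound 1 gives 14 uL/min. Its neighbour compound 2 `CCOc1cc([C@](O)(CCN(C)C)[C@H](c2cccc(C)c2)c2cc3cc(Br)ccc3nc2OC)cc(OC)n1` gives 7.8 uL/min, and the step of a 1.8-fold lower number from compound 1 to compound 2 (0.25 log units; within the scatter) keeps the two within the scatter of each other. Compound 3 `COc1cc([C@](O)(CCN(C)C)[C@@H](c2cc3cc(Br)ccc3nc2OC)c2cccc(OC)c2F)cc(SC)n1` differs from compound 1 by a change elsewhere: methylsulfanyl in place of ethoxy on an aromatic carbon. Going by the values given here, no measured step touches this position, so the step from compound 1 to compound 2 does not bear on it. With nothing to point either way, compound 3 is expected to show no change at the digits printed from compound 1 to compound 3 (within the scatter), giving an estimated 14 uL/min, between 7 uL/min and 28 uL/min.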

Compound 3, intrinsic clearance in a liver preparation (reported as CLH), per the amount of preparation that the assay uses: 20 uL/min
Compound 3: the middle estimate sits 1.4-fold (0.15 log units) below what was measured; the measured number falls inside the stated range.
By their numbers in this assay, from the lowest: compounds 2, 1 and 3 (each within the scatter of the next, the first and the last beyond it).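

In this assay, going by these compounds alone, methylsulfanyl in place of ethoxy on the aromatic carbon next to the ring nitrogen gives a 1.4-fold higher number from compound 1 to compound 3 (0.15 log units; within the scatter) and so gives the first reading at this position: this one exchange stays within the scatter. No measurement at hand explains this result. From the compounds shown here alone, whether an amine, a carboxylic acid or a longer chain at this position would move the number beyond the scatter remains open. So does whether methylsulfanyl would give the same result alongside the 3-methylphenyl group of compound 2.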